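From methoxy to methylsulfanyl: a question of half-life

The compounds below may be only part of what the source reports. "The series", "measured", "known", "first", "only" and "open" are said of these compounds alone.

Among the measured compounds shown here, in an ADME assay on microsomes from liver (Rattus norvegicus) for metabolic stability (a higher number here means that the compound lasts longer, a lower number that the compound disappears faster), compound 2 `COC[C@H](NC(=O)[C@H](CSC)NC(=O)c1cc(C)on1)C(=O)N[C@@H](CC(C)C)C(=O)[C@@]1(C)CO1` gives 1.11 h, the higher of the two numbers so far. Compound 1 `COC[C@H](NC(=O)c1cc(C)on1)C(=O)N[C@@H](CSC)C(=O)N[C@@H](CC(C)C)C(=O)[C@@]1(C)CO1` gives 0.518 h, and this gap lies beyond the usual scatter. Compound 3 `CSC[C@H](NC(=O)c1cc(C)on1)C(=O)N[C@@H](CSC)C(=O)N[C@@H](CC(C)C)C(=O)[C@@]1(C)CO1` has not yet been measured. It differs from compound 2 by a single swap, methylsulfanyl in place of methoxy on a saturated chain carbon, two bonds along the chain from an amide-type nitrogen and a carbonyl carbon. For the measured compounds named here, no measured pair shows this swap on its own, so any forecast in this assay remains loose. A modest fall in half-life is expected, about the size of the scatter, though no change beyond the scatter would be no surprise. The expected move is a 1.7-fold lower number from compound 2 to compound 3 (0.23 log units; within the scatter). For compound 3 the estimated half-life is 0.65 h, within a range from 0.3 h to 1.4 h.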

Compound 3, half-life: 0.132 h
Compound 3: middle estimate off by 4.9-fold (0.69 log units), on the high side; the whole stated range lies above it.
By their numbers in this assay, from the lowest: compound 3; then compound 1; then compound 2.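

Compound 1 and compound 2 carry their methoxy at different points of the chain, so the same swap can now be read twice in this assay, giving an 8.4-fold lower number from compound 2 to compound 3 (0.92 log units; beyond the scatter) and a 3.9-fold lower number from compound 1 to compound 3 (0.59 log units; beyond the scatter). Both steps run the same way and lie beyond the scatter, and compound 3, which has methylsulfanyl at both points and no methoxy, has the shortest half-life of the three. Nothing measured here gives a reason for this loss of half-life.

From the compounds shown here alone, whether a hydroxyl, an amine or a longer chain at either point would hold the half-life of compound 2 or lose it as methylsulfanyl does remains open. So does the question of which part of compound 3 is lost first in the microsomes.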